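Swapping the Piperidine Nitrogen Substituent in Compound 3

A few compounds are considered here, and "the series" means these few. Any claim that something is new, unique, unknown or untested is made for them only; others in the source may bear on it.

Three compounds have been measured in a functional assay on CHO-K1 cells for agonist activity at Glucose-dependent insulinotropic receptor (Mus musculus), read by HTRF and cAMP accumulation, with a stated time of 30 min; on this read-out lower numbers stand for an effect already at smaller amounts and higher numbers for an effect only at larger amounts of compound:
Compound 1, `CC(C)(C)OC(=O)N1CCC(CCCNc2ccc3c(c2)OCS3(=O)=O)CC1`, gives 266 nM.
Compound 2, `CC(C)(C)OC(=O)N1CCC(CCCNc2ccc3c(c2)NNS3(=O)=O)CC1`, gives 331 nM.
Compound 3, `COC(=O)c1cnc(N2CCC(CCCNc3ccc4c(c3)OCC4=O)CC2)nc1`, gives 139 nM.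

Compound 3 has the lowest of the three numbers. Its gap to compound 1 lies within the usual scatter, so the two cannot be ranked against each other; its gap to compound 2 lies beyond the scatter, so compound 3 does act at smaller amounts than compound 2 in this assay. For the measured compounds named here, none of these pairs differs in only one place, so no single structural step among the measured compounds can be read off.

Compound 4, `CC(C)c1nsc(N2CCC(CCCNc3ccc4c(c3)OCC4=O)CC2)n1`, has not yet been measured. It differs from compound 3 in one place: 3-isopropyl-1,2,4-thiadiazol-5-yl in place of 5-(methoxycarbonyl)pyrimidin-2-yl on an amine nitrogen in a ring. The shared core of compound 3 is kept, and only the group on the ring nitrogen changes. Going by the values given here, no measured pair shows the effect of such a swap, so the expectation rests on the values of compound 3 alone. Compound 4 is expected to give about 150 nM, within a range from 50 nM to 500 nM. The step of a 1.1-fold higher number from compound 3 to compound 4 (0.03 log units; within the scatter) that this estimate means is expected to stay within the scatter, with no clear direction.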

Compound 4, half-maximal effective concentration: 812 nM
Compound 4: middle estimate off by 5.4-fold (0.73 log units), on the low side; measured number above the stated range.
By their numbers in this assay, from the lowest: compounds 3, 1 and 2 (each within the scatter of the next, the first and the last beyond it); then compound 4.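

In this assay, for the compounds shown here, the swap of 5-(methoxycarbonyl)pyrimidin-2-yl for 3-isopropyl-1,2,4-thiadiazol-5-yl gives a 5.8-fold higher number from compound 3 to compound 4 (0.77 log units; beyond the scatter), the first single-place comparison in the set and a step beyond the scatter. It shows that the group on an amine nitrogen in a ring of the six-membered non-aromatic ring bears on this read-out, and that this particular exchange moves the number upward while the rest of compound 3 stays the same. The two groups differ at once in ring size, hetero atoms and their substituent, so the step cannot be assigned to any one of these features, and nothing measured here explains it.

As far as these compounds go, it remains open whether the higher number follows the ring or the substituent it carries, a question that a pyrimidin-2-yl ring bearing isopropyl, or a 1,2,4-thiadiazol-5-yl ring bearing methoxycarbonyl, would separate. Also open, from the compounds shown here alone, is how far the methoxycarbonyl group itself matters on the pyrimidine ring, for which a carboxylic acid or a nitrile at that spot would be a direct test.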